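The source may hold more compounds than are shown below. What is called first, only, known or untested is meant among the compounds shown, and "the series" means these compounds.

Within the data shown here, in a functional assay on HeLa cells (Homo sapiens) for antiproliferative activity, read by MTT assay, with a stated time of 6 days (a higher number here means a weaker inhibitor, a lower number a stronger inhibitor), compound 1 `CC(=O)O[C@@H]1C=CC(=O)O[C@@H]1[C@@H](COC(=O)c1ccc(Cl)cc1)OC(C)=O` gives 11000 nM, the highest number of the three compounds measured so far. Compound 3 `O=C1C=C[C@@H](OCc2ccccc2)[C@@H]([C@@H](COC(=O)/C=C/c2ccc([N+](=O)[O-])cc2)OCc2ccccc2)O1` gives 2650 nM and compound 2 `COc1ccc(/C=C/C(=O)OC[C@@H](OCc2ccccc2)[C@H]2OC(=O)C=C[C@H]2OCc2ccccc2)cc1` gives 1080 nM, both clearly lower, although each of them differs from compound 1 in more than one place.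

The next compound to consider is compound 4 `CC(=O)OC[C@@H](OC(C)=O)[C@H]1OC(=O)C=C[C@H]1OC(C)=O`, which has not yet been measured. Its structural change from compound 1 is methyl in place of 4-chlorophenyl on a carbonyl carbon, so that a (4-chlorophenyl)carbonyl becomes an acetyl.

Among the measured compounds shown here, only one measured step offers any guidance, and it is indirect. The step of a 2.5-fold higher number from compound 2 to compound 3 (0.39 log units; beyond the scatter) is modest and comes from nitro in place of methoxy on an aromatic carbon. It leaves the aromatic ring in place, whereas the change to compound 4 removes one. For the measured compounds named here, no measured pair shows the replacement of 4-chlorophenyl by methyl, so neither the size nor the direction of this change is established. The expectation is therefore for no large change from compound 1, with a slight lean towards a higher number.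

The estimated step is a 1.3-fold higher number from compound 1 to compound 4 (0.10 log units; within the scatter). For compound 4 the estimated value is 14000 nM, with an expected range from 4500 nM to 45000 nM.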

Compound 4, half-maximal inhibitory concentration: 2640 nM
Compound 4: middle estimate off by 5.3-fold (0.72 log units), on the high side; measured number below the stated range.
By their numbers in this assay, from the lowest: compound 2; then compounds 4 and 3 (each within the scatter of the next); then compound 1.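

In this assay, among these compounds, the step of a 4.2-fold lower number from compound 1 to compound 4 (0.62 log units; beyond the scatter) is the first measured change on this carbonyl carbon, as the earlier step of a 2.5-fold higher number from compound 2 to compound 3 (0.39 log units; beyond the scatter) only exchanged one group on an aromatic carbon and left the ring in place. It shows that the 4-chlorophenyl group is not needed for antiproliferative activity at this position: with the aromatic ring gone and a plain acetyl in its place, compound 4 is the stronger inhibitor of the pair, and the change runs clearly beyond the scatter. No measurement at hand explains why this replacement lowers the number.

The compounds shown do not separate the loss of the chlorine from the loss of the ring, nor do they show whether the trend continues on this carbonyl carbon with a longer chain such as propyl, or with an aminomethyl group. They also leave open whether the same replacement would have a similar effect on a compound carrying the benzyl groups of compound 2 and compound 3, since the step has been read only with acetyl groups elsewhere on the shared core.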